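A few compounds are considered here, and "the series" means these few. Any claim that something is new, unique, unknown or untested is made for them only; others in the source may bear on it.

Measured compounds:
Compound 1, `O=C(O)CCCCCCCCCn1nc(-c2ccccc2)c(-c2ccccc2)c1-c1ccccc1`, gives 5500 nM in a functional assay for inhibition, with Homo sapiens as the target; a lower number here means a stronger inhibitor, a higher number a weaker inhibitor.
Compound 2, `CCc1c(-c2ccccc2)nn(CCCCCCCCC(=O)O)c1-c1ccccc1`, gives in this assay only a limit, > 79000 nM.
Compound 3, `O=C(O)CCCCCCCCCn1cc(-c2ccccc2)c(-c2ccccc2)n1`, gives in this assay only a limit, > 81000 nM.

Going by the values given here, of the three values shown, compound 1 holds the only actual number; the two others are limits of the assay and not numbers. Among the compounds with values here, the one measured step between single-change neighbours is large: an at least 14-fold higher number from compound 1 to compound 3 (1.16 log units; beyond the scatter), the change being hydrogen in place of phenyl on an aromatic carbon. Compound 2 and compound 1 differ in more than one place, so only their two values can be compared, and one of them is a limit.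

Compound 4, `N#CCCCCCCCCn1nc(-c2ccccc2)c(-c2ccccc2)c1-c1ccccc1`, differs from compound 1 in a single place: cyano in place of carboxymethyl on a saturated chain carbon, eight bonds along the chain from an aromatic nitrogen. Within the data shown here, the measured step concerns a ring substituent, not the chain end, so it does not bear on this change, and no measured step does. Without a guiding step, a move toward a higher number is expected, estimated as a 3.6-fold higher number from compound 1 to compound 4 (0.56 log units; beyond the scatter) in this assay. Compound 4 is therefore estimated at 20000 nM, with a range from 5000 nM to 80000 nM.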

Compound 4, half-maximal inhibitory concentration: > 72000 nM
Compound 4 gave a limit, no number; the forecaster's own chance of this, stated with the estimate: 40%; middle value at least 3.6-fold (0.55 log units) away from the limit.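

Cyano in place of carboxymethyl, on a saturated chain carbon, eight bonds along the chain from an aromatic nitrogen, gives an at least 13-fold higher number from compound 1 to compound 4 (1.11 log units; beyond the scatter). Going by these compounds alone, the earlier measured step concerned a ring substituent, so this is the first sign that the chain end also carries weight in this assay, with the shared core left unchanged. Compound 4 gives only a limit of the assay, not a number, so the step marks a minimum size and the true value stays unknown: the limit of > 72000 nM in this assay, at which 1 of the 4 values shown sits.

The compounds shown leave open whether another group at the chain end, such as a primary amide, a methyl ester or a tetrazole, would give a measurable number. They also cannot say why the cyano compound falls out of range, or whether any chain end without a carboxylic acid would do the same.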